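Dichlorobenzyl Variation at a Cytotoxicity Ceiling

This account rests on a few compounds, and the source may have more. Where it says the series, first, only, none or still open, it means among the compounds named here.

Measured so far:
compound 1, `Cn1cc(SCc2nnc(SCc3ccccc3)n2-c2c(Cl)cccc2Cl)c2ccccc21` — > 100000 nM
compound 2, `Cn1cc(SCc2nnc(SCc3ccccc3C#N)n2-c2c(Cl)cccc2Cl)c2ccccc21` — 78600 nM
compound 3, `Cn1cc(SCc2nnc(SCc3cccc(Cl)c3Cl)n2-c2c(Cl)cccc2Cl)c2ccccc21` — > 100000 nM

All three share one core and differ only in the benzyl group joined through sulfur. In a toxicity assay on HEK-293T cells (Homo sapiens) for cytotoxicity, read by CCK-8 assay, with a stated time of 48 h (a higher number here means that more compound is tolerated, a lower number that less compound is tolerated), compound 1 gives > 100000 nM, which is a limit of the assay rather than a number. Compound 3 likewise gives > 100000 nM, again a limit. Between them, a step that the two limits leave unreadable from compound 1 to compound 3. Compound 2, with cyano in place of hydrogen on an aromatic carbon, gives 78600 nM; here an at least 1.2-fold lower number from compound 1 to compound 2 (0.10 log units; that floor lies within the scatter), and an at least 1.2-fold higher number from compound 2 to compound 3 (0.10 log units; that floor lies within the scatter). The picture is flat: the limit of > 100000 nM in this assay, at which 2 of the 3 values shown sit.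

Compound 4, `Cn1cc(SCc2nnc(SCc3cc(Cl)ccc3Cl)n2-c2c(Cl)cccc2Cl)c2ccccc21`, carries the change (2,5-dichlorophenyl in place of phenyl on a saturated chain carbon bound to a sulfur). The nearest guide is the step from compound 1 to compound 3, where a dichlorinated benzyl also replaced plain benzyl and the two limits left the size unreadable. No step beyond the scatter is therefore expected in this assay, and compound 4 is expected to sit at or near the ceiling again, with the step of a number no higher from compound 1 to compound 4 (the limit leaves the size open) expected to be small. Compound 4 is estimated at 100000 nM, within 55000 nM to 200000 nM.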

Compound 4, half-maximal cytotoxic concentration: > 100000 nM
Compound 4: no number, only a limit; the forecaster's own chance of this, stated with the estimate: 70%; the middle value lies on the limit itself.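

Compound 4 gives a limit rather than a number in this assay, so a second dichlorinated benzyl, with its chlorines placed differently from those of compound 3, reaches the same ceiling as plain benzyl: the limit of > 100000 nM in this assay, at which 3 of the 4 values shown sit. The steps from compound 1 and from compound 3 to compound 4 cannot be read, since both ends of each are limits. Among the compounds shown here, the only readable comparison is with the nitrile-bearing compound, and it stays small: an at least 1.2-fold higher number from compound 2 to compound 4 (0.10 log units; that floor lies within the scatter).

The compounds shown leave open how much compound the cells would tolerate beyond this ceiling, and so whether the benzyl groups differ from one another at all. Also open, as far as these compounds go, is whether an amine or a carboxylic acid on the benzyl ring, or a longer chain in place of the benzyl group, would bring a clear change in this assay.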